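Biaryl amide series: cytotoxicity notes toward compound 4

This account rests on a few compounds, and the source may have more. Where it says the series, first, only, none or still open, it means among the compounds named here.

Measured so far:
compound 1 `CC(=O)c1cccc(-c2ccc(C(=O)N(Cc3cccc(OCCCCCC(=O)O)c3)C(C)C)cc2)c1` — in an ADME assay on HEK293 cells (Homo sapiens) for cytotoxicity, read by CellTiter-Glo and resazurin assay, with a stated time of 72 h (on this read-out higher numbers stand for an effect only at larger amounts of compound and lower numbers for an effect already at smaller amounts), compound 1 shows only a limit, > 26000 nM.
compound 2 `CC(C)N(Cc1cccc(OCCCCCC(=O)O)c1)C(=O)c1ccc(-c2cc3ccccc3n2S(=O)(=O)c2ccccc2)cc1` — in this assay compound 2 shows only a limit, > 26000 nM.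
compound 3 `CCOC(=O)CCCCCOc1cccc(CN(C(=O)c2ccc(-c3ccc4ccccc4c3)cc2)C(C)C)c1` — in this assay compound 3 shows only a limit, > 26000 nM.

Compound 3 stands where every measured value stands: the limit of > 26000 nM in this assay, at which 3 of the 3 values shown sit. For the measured compounds named here, no pair of measured compounds differing in one place exists, so nothing is known about how any change at this position moves the read-out. Compound 4 `CCOC(=O)CCCCCOc1cccc(CN(C(=O)c2ccc(-c3ccc4cc[nH]c4c3)cc2)C(C)C)c1` differs from compound 3 by 1H-indol-6-yl in place of naphthalen-2-yl on an aromatic carbon. With all measured values at a limit, no step beyond the scatter is expected. The step is estimated as a step that the limit leaves unreadable from compound 3 to compound 4. Compound 4 is accordingly expected to give 30000 nM, with a range from 12000 nM to 80000 nM, most likely again as a limit in this assay.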

Compound 4, half-maximal effective concentration: > 26000 nM
Compound 4 ended at the assay's limit; the forecaster's own chance of this, stated with the estimate: 85%; the middle value lies beyond the limit too.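

In this assay, for the compounds shown here, compound 3 and compound 4 both sit at a limit, and no step between them can be read. The compounds shown leave open whether 1H-indol-6-yl and naphthalen-2-yl differ at all on this read-out, and at what concentration any of these compounds would show an effect.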